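The source may report more compounds than this note shows. Statements on the series, on what has been measured and on what is new or still open speak of the compounds shown alone.

Measured so far:
Compound 1, `COc1ccc(/C=C2\NC(=O)N(CCCCN3CCN(c4cccc(Cl)c4Cl)CC3)C2=O)cc1OC`, gives 0.8 nM in an assay on CHO cells for displacement of a labelled ligand from 5-hydroxytryptamine receptor 7 (Homo sapiens), read by scintillation counting, with a stated time of 60 min; a lower number here means a stronger inhibitor, a higher number a weaker inhibitor.
Compound 2, `COc1ccc(/C=C2\NC(=O)N(CCCCN3CCN(c4ccccc4OC)CC3)C2=O)cc1OC1CCCC1`, gives 1 nM in this assay.

Of these two numbers, compound 2 has the higher one, yet its gap to compound 1 lies within the scatter, so the two cannot be told apart. Compound 3, `COc1ccc(/C=C2\NC(=O)N(CCCCN3CCN(c4cccc(Cl)c4Cl)CC3)C2=O)cc1OC1CCCC1`, has not been measured. It differs from compound 2 by 2,3-dichlorophenyl in place of 2-methoxyphenyl on an amine nitrogen in a ring. For the measured compounds named here, no step between measured compounds that differ in one place is available. The step of a 1.3-fold lower number from compound 2 to compound 3 (0.10 log units; within the scatter) is expected to be none beyond the scatter. Compound 3 is therefore expected to give 0.8 nM, within 0.3 nM to 2.5 nM.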

Compound 3, inhibition constant: 125 nM
Estimate against measurement, compound 3: 160-fold (2.19 log units) below, outside the stated range (above it).
By their numbers in this assay, from the lowest: compounds 1 and 2 (each within the scatter of the next); then compound 3.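

With cyclopentyl on the oxygen, the move from 2-methoxyphenyl to 2,3-dichlorophenyl on the amine nitrogen gives a large loss in this assay (a 130-fold higher number from compound 2 to compound 3 (2.10 log units; beyond the scatter)). With 2,3-dichlorophenyl on that nitrogen, cyclopentyl in place of methyl on the oxygen also gives a large loss (a 160-fold higher number from compound 1 to compound 3 (2.19 log units; beyond the scatter)). Each group therefore matters greatly when the other is present, which compounds 1 and 2 could not show by themselves.

Nothing shown explains why these changes have such large effects. Also open, from the compounds shown here alone, is how a group of intermediate size on that oxygen, such as ethyl or cyclopropyl, would behave alongside 2,3-dichlorophenyl.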